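Swapping the aryl group on the ring nitrogen: a pyridyl step

The source may hold more compounds than are shown below. What is called first, only, known or untested is meant among the compounds shown, and "the series" means these compounds.

Of the compounds shown here, three sharing one core have been tested in a functional assay on CHO cells with adenosine receptor A1 (Homo sapiens) as the target, read by cAMP accumulation and immunoassay, with a stated time of 6 min, tested at 0.1 uM; a lower number here means a stronger effect, a higher number a weaker effect of the compound at the concentration tested. Compound 1 `Nc1scc(CN2CCN(c3cc(Cl)cc(Cl)c3)CC2)c1C(=O)c1ccc(Cl)cc1` gives -22%, compound 2 `Nc1scc(CN2CCN(c3ccc([N+](=O)[O-])cc3)CC2)c1C(=O)c1ccc(Cl)cc1` gives -13%, and compound 3 `Nc1scc(CN2CCN(c3ccc(Cl)c(C(F)(F)F)c3)CC2)c1C(=O)c1ccc(Cl)cc1` gives -12%. On these numbers compound 3 stands highest of the three, nearest to compound 2 and furthest from compound 1, yet both gaps lie within the scatter, so the three compounds cannot be ordered.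

Compound 4 `Nc1scc(CN2CCN(c3ccncc3)CC2)c1C(=O)c1ccc(Cl)cc1` is not yet measured. It differs from compound 3 in one place: pyridin-4-yl in place of 4-chloro-3-(trifluoromethyl)phenyl on an amine nitrogen in a ring. Among the measured compounds shown here, every measured step so far also exchanged the aryl group on this ring nitrogen. The step of a number 9 percentage points higher from compound 1 to compound 2 (within the scatter), the step of a number 10 percentage points higher from compound 1 to compound 3 (within the scatter) and the step of a number 1 percentage points higher from compound 2 to compound 3 (within the scatter) all stayed within the scatter, even though the groups exchanged were quite different. For the measured compounds named here, no measured step reaches beyond the scatter, so from compound 3 to compound 4 no change beyond the scatter is expected either, which is what the estimated step of no change at the digits printed from compound 3 to compound 4 (within the scatter) expresses. Compound 4 is therefore expected to give about -12% in this assay, with a range from -30% to 8%.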

Compound 4, a percentage reported as activity, at one concentration (the size of the read-out at that concentration, not a potency): 1.4%
Compound 4: middle estimate off by 13.4 percentage points, on the low side, and the stated range covers the measured number.
By their numbers in this assay, from the lowest: compounds 1, 2 and 3 (each within the scatter of the next); then compound 4.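

Pyridin-4-yl is the only one of the four aryl groups at this position that moves the number beyond the scatter, giving a number 13.4 percentage points higher from compound 3 to compound 4 (beyond the scatter) and a number 14.4 percentage points higher from compound 2 to compound 4 (beyond the scatter) and a number 23.4 percentage points higher from compound 1 to compound 4 (beyond the scatter) in this assay so compound 4 shows the weakest effect of the four at the concentration tested. The position is therefore not indifferent to its aryl group, although these steps are modest and the three substituted phenyl groups remain within the scatter of one another. No measurement shown here gives a reason for the shift.

Compound 4 brings in a ring nitrogen and also carries no substituent on its aryl ring, and the compounds shown do not separate these two changes. Unsubstituted phenyl would part them, and pyridin-3-yl would show whether the place of the ring nitrogen matters.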